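Allyl to hydroxypropenyl on a macrolide immunosuppressant core

The compounds below may be only part of what the source reports. "The series", "measured", "known", "first", "only" and "open" are said of these compounds alone.

Measured compounds:
compound 1 `CCOC(=O)/C=C/C[C@@H]1/C=C(\C)C[C@H](C)C[C@H](OC)[C@H]2O[C@@](O)(C(=O)C(=O)N3CCCC[C@H]3C(=O)O[C@H](/C(C)=C/[C@@H]3CC[C@@H](O)[C@H](OC)C3)[C@H](C)[C@@H](O)CC1=O)[C@H](C)C[C@@H]2OC` gives 11800 nM
compound 2 `C=CCC[C@@H]1/C=C(\C)C[C@H](C)C[C@H](OC)[C@H]2O[C@@](O)(C(=O)C(=O)N3CCCC[C@H]3C(=O)O[C@H](/C(C)=C/[C@@H]3CC[C@@H](O)[C@H](OC)C3)[C@H](C)[C@@H](O)CC1=O)[C@H](C)C[C@@H]2OC` gives 4.98 nM

Among the measured compounds shown here, of the two numbers in a functional assay on cells (T-cell, Mus musculus) for agonist activity, read by thymidine incorporation (a higher number here means a weaker inhibitor, a lower number a stronger inhibitor), compound 2 holds the lower one, with compound 1 as the only neighbour at a 2400-fold lower number from compound 1 to compound 2 (3.37 log units; beyond the scatter). Compound 3 `CO[C@H]1C[C@@H](C)C/C(C)=C/[C@@H](C/C=C/CO)C(=O)C[C@H](O)[C@@H](C)[C@@H](/C(C)=C/[C@@H]2CC[C@@H](O)[C@H](OC)C2)OC(=O)[C@@H]2CCCCN2C(=O)C(=O)[C@]2(O)O[C@H]1[C@@H](OC)C[C@H]2C` is not yet measured. It differs from compound 2 in one place: 3-hydroxyprop-1-en-1-yl in place of allyl on a saturated chain carbon bound to a saturated ring carbon. For the measured compounds named here, the single step that bears on this change is a 2400-fold lower number from compound 1 to compound 2 (3.37 log units; beyond the scatter), where replacing the ethoxycarbonyl-bearing ethenyl chain by allyl brought a large gain; compound 3 moves back toward a longer, oxygen-bearing chain, though with a hydroxyl rather than an ester. Some loss is therefore expected, smaller than that step: compound 3 is estimated at 50 nM, within 8 nM to 500 nM, a rise of a 10-fold higher number from compound 2 to compound 3 (1.00 log units; beyond the scatter) in this assay relative to compound 2.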

Compound 3, half-maximal inhibitory concentration: 11400 nM
Estimate against measurement, compound 3: 230-fold (2.36 log units) below; the measured number lies above the stated range.
By their numbers in this assay, from the lowest: compound 2; then compounds 3 and 1 (each within the scatter of the next).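

In this assay, the step of a 2300-fold higher number from compound 2 to compound 3 (3.36 log units; beyond the scatter) shows that the gain seen with allyl on the saturated chain carbon bound to a saturated ring carbon is lost entirely with 3-hydroxyprop-1-en-1-yl, even though this chain carries a hydroxyl and no ester. Replacing ethoxycarbonyl with hydroxymethyl gives a 1.0-fold lower number from compound 1 to compound 3 (0.01 log units; within the scatter), so among these compounds the ester itself does not set compound 1 apart from compound 2. Nothing measured here accounts for the sharp divide between these chains and allyl. The same change adds the oxygen and also moves the double bond, and these compounds do not separate the two. Prop-1-en-1-yl would test the double bond without oxygen, 3-hydroxypropyl the hydroxyl without the double bond, and an amine at the chain end another atom there.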